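Replacing a chlorinated phenyl group on a ring nitrogen

A few compounds are considered here, and "the series" means these few. Any claim that something is new, unique, unknown or untested is made for them only; others in the source may bear on it.

In a toxicity assay on L3.6pl cells (Homo sapiens) for inhibition, read by ATP content, with a stated time of 72 h (a higher number here means a weaker inhibitor, a lower number a stronger inhibitor), compound 1 (`COc1ccc(C(=O)Nc2ccc(N3CCN(c4cc(Cl)ccc4C)CC3)cc2C(=O)O)cc1`) gives 16800 nM and compound 2 (`COc1ccccc1C(=O)Nc1ccc(N2CCN(c3cc(Cl)ccc3C)CC2)cc1C(=O)O`) gives 29100 nM as its half-maximal inhibitory concentration. These two values lie within the usual scatter of each other, so compound 2 cannot be ranked apart from compound 1.

Compound 3 (`COc1ccccc1C(=O)Nc1ccc(N2CCN(c3cccc(C)c3C)CC2)cc1C(=O)O`) differs from compound 2 in one place (2,3-dimethylphenyl in place of 5-chloro-2-methylphenyl on an amine nitrogen in a ring), with 2,3-dimethylphenyl in place of 5-chloro-2-methylphenyl on an amine nitrogen in a ring.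

Among the measured compounds shown here, the only measured step is a 1.7-fold higher number from compound 1 to compound 2 (0.24 log units; within the scatter) and it stays within the scatter. For the measured compounds named here, that step put 2-methoxyphenyl in place of 4-methoxyphenyl on a carbonyl carbon, so no measurement yet shows what a change on the ring nitrogen does. Compound 2 at 29100 nM is therefore the anchor, and no shift beyond the scatter from that value is expected in this assay for the new compound. The expected change is a 1.2-fold lower number from compound 2 to compound 3 (0.07 log units; within the scatter) by this estimate. For compound 3 the estimate is 25000 nM with an expected range from 10000 nM to 60000 nM in this measurement.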

Compound 3, half-maximal inhibitory concentration: 22900 nM
Beside the measured number, compound 3's estimate is 1.1-fold (0.04 log units) above it, within the range that was stated.
By their numbers in this assay, from the lowest: compounds 1, 3 and 2 (each within the scatter of the next).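

Among the compounds shown here, this step is the first look at the ring nitrogen, and in this assay it gives a 1.3-fold lower number from compound 2 to compound 3 (0.10 log units; within the scatter) when 2,3-dimethylphenyl replaces 5-chloro-2-methylphenyl. The group that leaves and the group that enters each have one six-membered aromatic ring of carbon only and the same count of heavy atoms, but the entering group has no chlorine, so in this one pair, losing the chlorine gives no change that can be told from the scatter between repeated measurements. Nothing available here gives a measured property of either group, so no explanation can be offered for this result.

Both groups on the ring nitrogen are methyl-bearing phenyl rings, so these compounds leave open whether something of a different kind at that place, such as a benzyl group, a pyridine ring or a short chain ending in an amine, would move the number beyond the scatter. All three compounds also carry the same carboxylic acid, so what a methyl ester or a primary amide in its place would do cannot be read from them.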